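A few compounds are considered here, and "the series" means these few. Any claim that something is new, unique, unknown or untested is made for them only; others in the source may bear on it.

Measured in a functional assay on MDA-MB-231 cells (Homo sapiens) for cytotoxicity, read by MTT assay, with a stated time of 72 h; a higher number here means a weaker inhibitor, a lower number a stronger inhibitor:

compound 1, `N=C(Nc1ccccc1)c1cc2c(-c3ccccc3)n[nH]c2c(NC2CCCCC2)n1` — 1710 nM
compound 2, `CN1CCN(c2ccc(NC(=N)c3cc4c(-c5ccccc5)n[nH]c4c(NC4CCCCC4)n3)cc2)CC1` — 1500 nM
compound 3, `COc1ccc(Cn2nc(-c3ccccc3)c3cc(C(=N)Nc4ccccc4)nc(NC4CCCCC4)c32)cc1` — 3400 nM

Compound 1 holds the second highest of the three numbers; the nearest is compound 2 with a 1.1-fold lower number from compound 1 to compound 2 (0.06 log units; within the scatter), the furthest compound 3 with a 2.0-fold higher number from compound 1 to compound 3 (0.30 log units; within the scatter). Both of those steps fall within the scatter, so the three measured compounds are indistinguishable on this assay.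

Compound 4, `N=C(Nc1ccccc1)c1cc2c(-c3ccccc3)n[nH]c2cn1`, differs from compound 1 by hydrogen in place of cyclohexylamino on an aromatic carbon. Neither measured step touches this position: the step from compound 1 to compound 2 alters a distal aromatic carbon, and the step from compound 1 to compound 3 alters the aromatic nitrogen. Within the data shown here, no measured pair therefore bears directly on the removal of the cyclohexylamino group, and the expectation rests only on the size of the group lost. With a group of this size leaving the shared core, a weaker result for compound 4 is expected, namely a 2.6-fold higher number from compound 1 to compound 4 (0.42 log units; beyond the scatter). The estimate for compound 4 in this assay is 4500 nM, with a range from 1200 nM to 16000 nM.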

Compound 4, half-maximal inhibitory concentration: 11000 nM
Beside the measured number, compound 4's estimate is 2.4-fold (0.39 log units) below it, within the range that was stated.
By their numbers in this assay, from the lowest: compounds 2, 1 and 3 (each within the scatter of the next, the first and the last beyond it); then compound 4.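

Among these compounds, removing the cyclohexylamino group is the first change whose effect on this assay lies beyond the scatter, with a 6.4-fold higher number from compound 1 to compound 4 (0.81 log units; beyond the scatter) as the step, whereas the 4-methylpiperazin-1-yl and 4-methoxybenzyl changes stayed within it. This position, on an aromatic carbon next to the ring nitrogen, is therefore the only one of the three places shown where a change separates two compounds on this read-out. No measurement at hand accounts for this step, so its cause stays unassigned.

On these data alone, whether the step depends on the carbon ring of cyclohexylamino or on its amine nitrogen stays open; a plain amino group, methylamino or cyclopentylamino at this carbon would separate those readings. Also open, as far as these compounds go, is whether the same removal gives a similar step alongside the 4-methylpiperazin-1-yl or 4-methoxybenzyl groups.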